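Chloromethyl for furan-2-yl on the carbonyl carbon

The source may hold more compounds than are shown below. What is called first, only, known or untested is meant among the compounds shown, and "the series" means these compounds.

In a functional assay on MV4-11 cells (Homo sapiens) for cytotoxicity, read by MTT assay, with a stated time of 72 h (on this read-out higher numbers stand for weaker inhibition and lower numbers for stronger inhibition), compound 3 (`CCOC(=O)c1csc2nc(-c3ccc(NC(=O)c4ccco4)cc3)cn12`) gives 9920 nM, the higher of the two true numbers in the series. The nearest neighbour of compound 3 is compound 1 (`CCOC(=O)c1csc2nc(-c3ccc(NC(=O)Nc4ccc(Br)cn4)cc3)cn12`) at 2440 nM. Compound 2 (`CCCS(=O)(=O)Nc1ccc(-c2cn3c(C(=O)OCC)csc3n2)cc1`) gives > 20000 nM, which is a limit of the assay and not a number.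

Compound 4 (`CCOC(=O)c1csc2nc(-c3ccc(NC(=O)CCl)cc3)cn12`) has chloromethyl in place of furan-2-yl on a carbonyl carbon. For the measured compounds named here, no measured compound carries chloromethyl. The closest guide is a 4.1-fold higher number from compound 1 to compound 3 (0.61 log units; beyond the scatter), a modest change beyond the scatter made on the same carbonyl carbon. The other two steps change the group on the nitrogen: an at least 8.1-fold higher number from compound 1 to compound 2 (0.91 log units; beyond the scatter) is a floor, and an at least 2.0-fold lower number from compound 2 to compound 3 (0.30 log units; that floor lies within the scatter) is a floor within the scatter.

A modest step to a lower number is therefore expected in this assay, although the direction is only weakly supported. The expected change is a 2.0-fold lower number from compound 3 to compound 4 (0.30 log units; within the scatter). For compound 4 the estimate is 5000 nM, with an expected range of 1500 nM to 16000 nM.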

Compound 4, half-maximal inhibitory concentration: 9070 nM
Beside the measured number, compound 4's estimate is 1.8-fold (0.26 log units) below it, within the range that was stated.
By their numbers in this assay, from the lowest: compound 1; then compounds 4 and 3 (each within the scatter of the next). At a limit, above all of these: compound 2.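

In this assay, chloromethyl in place of furan-2-yl on the carbonyl carbon gives a 1.1-fold lower number from compound 3 to compound 4 (0.04 log units; within the scatter), so these two groups, one with a ring and one without, cannot be told apart here, while the (5-bromopyridin-2-yl)amino group stands apart from chloromethyl with a 3.7-fold higher number from compound 1 to compound 4 (0.57 log units; beyond the scatter). On the nitrogen, (chloromethyl)carbonyl in place of propylsulfonyl gives an at least 2.2-fold lower number from compound 2 to compound 4 (0.34 log units; beyond the scatter), which extends the earlier comparison of the acyl and sulfonyl groups to a second acyl group. The value of compound 2 is a limit of the assay and not a number: the limit of > 20000 nM in this assay, at which 1 of the 4 values shown sits.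

On these data alone, what a plain methyl, a longer chain or a morpholine ring would give on this carbonyl carbon stays open. Also open, as far as these compounds go, is whether any group other than (5-bromopyridin-2-yl)amino can match compound 1 here.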